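From Ester to Amide: Expecting the Next Measurement

The source may report more compounds than this note shows. Statements on the series, on what has been measured and on what is new or still open speak of the compounds shown alone.

In an assay on isolated protein for inhibition of protein kinase C zeta type (Homo sapiens), with stated times of 1 h and 2.5 min, tested at 30 uM (on this read-out higher numbers stand for more inhibition at the one concentration tested (going by the name of the read-out) and lower numbers for less inhibition), compound 3 `COc1ccc(-c2csc(N)c2C(=O)OCc2ccccc2F)cc1OC` gives 100%, level with compound 1 `CCOC(=O)c1c(-c2ccc(OC)c(OC)c2)csc1N`, which gives 100%. Compound 2 `COc1ccc(-c2csc(N)c2C(=O)OCc2ccccc2C)cc1OC` gives 64%, and the step of a number 36 percentage points higher from compound 2 to compound 3 (beyond the scatter) is large, so compounds 1 and 3 together stand at the top of the three numbers. Compound 4 `CCNC(=O)c1c(-c2ccc(OC)c(OC)c2)csc1N` has not yet been measured in this assay. It differs from compound 3 by ethylamino in place of (2-fluorobenzyl)oxy on a carbonyl carbon. Among the compounds with values here, no measured step touches this carbonyl partner: the steps of no change at the digits printed from compound 1 to compound 3 (within the scatter) and a number 36 percentage points lower from compound 1 to compound 2 (beyond the scatter) only swap what sits on the saturated chain carbon bound to the oxygen. Without a direct guide, a moderate loss is expected, and the number cannot rise because compound 3 already gives 100%. Compound 4 is therefore estimated at 70%, between 30% and 100%. This expectation means a step of a number 30 percentage points lower from compound 3 to compound 4 (beyond the scatter).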

Compound 4, a percentage reported as inhibition, at one concentration (the size of the read-out at that concentration, not a potency): 50%
Compound 4: the middle estimate sits 20 percentage points above what was measured, within the range that was stated.
By their numbers in this assay, from the lowest: compound 4; then compound 2; then compounds 1 and 3 (each within the scatter of the next).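

In this assay the change to ethylamino on a carbonyl carbon lowers the number from every ester shown: a number 50 percentage points lower from compound 1 to compound 4 (beyond the scatter) and a number 50 percentage points lower from compound 3 to compound 4 (beyond the scatter) and also a number 14 percentage points lower from compound 2 to compound 4 (beyond the scatter) even though that ester already stood lowest. The earlier steps shown here changed only the group on the ester oxygen and ranged from no change to a clear loss, whereas here all three esters stand above the one amide. No measured evidence explains this drop.

With a single amide shown, it stays open whether the loss goes with the amide link itself or with its small ethyl group. A 2-fluorobenzylamino group on the same carbonyl carbon would help separate the two.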